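Stripping the Ring Nitrogen Substituent Bare: What to Expect

The source may report more compounds than this note shows. Statements on the series, on what has been measured and on what is new or still open speak of the compounds shown alone.

Measured compounds:
Compound 1 `NCCCCN(C[C@H]1CN(S(=O)(=O)c2ccc(Cl)cc2)CCN1)[C@H]1CCCc2cccnc21` gives 2 nM in a functional assay on Chem-1 cells for antagonist activity at C-X-C chemokine receptor type 4 (Homo sapiens), read by calcium flux; a higher number here means a weaker inhibitor, a lower number a stronger inhibitor.
Compound 2 `NCCCCN(C[C@H]1CN(C(=O)Nc2ccccc2)CCN1)[C@H]1CCCc2cccnc21` gives 21000 nM in this assay.

Within the data shown here, compound 2 stands at the higher of the two numbers, meaning it is the weaker inhibitor; the single measured step, an 11000-fold higher number from compound 1 to compound 2 (4.02 log units; beyond the scatter), is large. Compound 3 `NCCCCN(C[C@H]1CNCCN1)[C@H]1CCCc2cccnc21` differs from compound 2 in one place: hydrogen in place of phenylcarbamoyl on an amine nitrogen in a ring. Among the measured compounds shown here, no measured step removes a substituent from this ring nitrogen altogether, so the only guidance is indirect. The step from compound 1 to compound 2 shows that what sits on this nitrogen matters greatly, and that the phenylcarbamoyl group is poorly tolerated. A bare nitrogen is a third, untested option, so a step in either direction is conceivable, with a gain more plausible than a further loss. Compound 3 is therefore expected to land at 1500 nM, within a wide range from 50 nM to 30000 nM, a change of a 14-fold lower number from compound 2 to compound 3 (1.15 log units; beyond the scatter) that is only an estimate.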

Compound 3, half-maximal inhibitory concentration: 255 nM
Compound 3: middle estimate off by 5.9-fold (0.77 log units), on the high side; the range from low to high includes it.
By their numbers in this assay, from the lowest: compound 1; then compound 3; then compound 2.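

With hydrogen on this ring nitrogen, the comparison gains a baseline in this assay, and the two substituents turn out to pull in opposite directions: hydrogen in place of phenylcarbamoyl gives an 82-fold lower number from compound 2 to compound 3 (1.92 log units; beyond the scatter), whereas hydrogen in place of (4-chlorophenyl)sulfonyl gives a 130-fold higher number from compound 1 to compound 3 (2.11 log units; beyond the scatter). Phenylcarbamoyl is therefore more than a weaker partner for this nitrogen, as it gives a weaker inhibitor than no substituent at all, while (4-chlorophenyl)sulfonyl gives a much stronger one. No measurement here explains either shift.

The compounds shown change the linking group and the chlorine together, so it remains open whether the sulfonyl link or the chlorine carries the gain, which a plain phenylsulfonyl group or a 4-chlorophenylcarbamoyl group could help separate. On these data alone, how a small group such as methyl or acetyl would compare with hydrogen also remains open.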